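Shortening the hydroxyalkylamino arm on the core of compound 1

The source may report more compounds than this note shows. Statements on the series, on what has been measured and on what is new or still open speak of the compounds shown alone.

Measured in a toxicity assay on the whole organism (J774 cells) for cytotoxicity, with Mus musculus as the target, read by MTT assay, with a stated time of 24 h, tested at 30 uM; on this read-out lower numbers stand for a stronger effect and higher numbers for a weaker effect at the one concentration tested:
compound 1 `CCCCCCCCCO[C@@H]1[C@@H](N)[C@@H](OCC(O)CNCCCO)O[C@H](CN)[C@H]1OCCCCCCCCC` gives 13.7%
compound 2 `CCCCCCCCCO[C@@H]1[C@@H](N)[C@@H](O[C@H]2[C@H](O)[C@@H](O)[C@H](N)C[C@@H]2N)O[C@H](CN)[C@H]1OCCCCCCCCC` gives 48.6%

Among the compounds with values here, compound 1 stands lowest of the two numbers, the stronger read-out; the only neighbour, compound 2, lies higher by a number 34.9 percentage points higher from compound 1 to compound 2 (beyond the scatter), a change in which the whole side group on an oxygen on a saturated carbon is exchanged for a ring.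

Compound 3 `CCCCCCCCCO[C@@H]1[C@@H](N)[C@@H](OCC(O)CNCCO)O[C@H](CN)[C@H]1OCCCCCCCCC` differs from compound 1 by hydroxy in place of hydroxymethyl on a saturated chain carbon, two bonds along the chain from an amine nitrogen. Within the data shown here, no measured step bears on this change: the one step in hand replaces the entire arm rather than shortening its hydroxyalkyl chain, so its size says nothing about a one-carbon cut within that arm. With the side group otherwise kept and the shared core untouched, the expectation for compound 3 is a step of a number 2.3 percentage points higher from compound 1 to compound 3 (within the scatter), that is, no change beyond the scatter in this assay. Compound 3 is therefore estimated at 16%, expected to fall between 6% and 30%.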

Compound 3, a percentage reported as activity, at one concentration (the size of the read-out at that concentration, not a potency): 10.1%
For compound 3 the middle estimate is 5.9 percentage points above the measured one, and the stated range covers the measured number.
By their numbers in this assay, from the lowest: compounds 3 and 1 (each within the scatter of the next); then compound 2.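

In this assay the change from (3-hydroxypropyl)amino to (2-hydroxyethyl)amino gives a number 3.6 percentage points lower from compound 1 to compound 3 (within the scatter) and so shows that shortening the arm at this saturated chain carbon, two bonds along the chain from an amine nitrogen, moves the read-out by no more than the scatter. The large gap to the ring-bearing compound also holds with the shorter arm, as a number 38.5 percentage points lower from compound 2 to compound 3 (beyond the scatter) shows, so among these three compounds both hydroxyalkylamino arms stand apart from the 4,6-diamino-2,3-dihydroxycyclohexyl group. Nothing in hand gives a cause for either step.

Still open, going by these compounds, is whether a longer hydroxyalkyl chain would stay within the same range. Also open, on these data alone, is what happens when an amine or a carboxylic acid takes the place of the terminal hydroxy on the arm.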